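From cyclopropyl to phenyl: an expected half-life

A few compounds are considered here, and "the series" means these few. Any claim that something is new, unique, unknown or untested is made for them only; others in the source may bear on it.

Compound 1 `CC(C)(/C=C1\OC(=O)NC1=O)c1ccc(-c2ccc3cccc(F)c3c2)[nH]c1=O`: in an ADME assay on microsomes from liver (Rattus norvegicus) for metabolic stability (on this read-out lower numbers stand for a shorter-lived compound and higher numbers for a longer-lived compound), compound 1 gives > 3 h, a limit of the assay.
Compound 2 `CC(C)/C(=C1\C(=O)NC(=O)N1C)c1ccc(-c2ccc3cccc(F)c3c2)[nH]c1=O`: in this assay compound 2 gives > 3 h, a limit of the assay.
Compound 3 `O=C1NC(=O)/C(=C/C(c2ccc(-c3ccc4cccc(F)c4c3)[nH]c2=O)C2CC2)O1`: in this assay compound 3 gives > 3 h, a limit of the assay.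

Compound 3 thus stands at the limit of > 3 h in this assay, at which 3 of the 3 values shown sit. Among the compounds with values here, no numbered half-life separates it from compound 1 or compound 2, and no step between measured compounds can be drawn. Compound 4 `O=C1NC(=O)/C(=C/C(c2ccccc2)c2ccc(-c3ccc4cccc(F)c4c3)[nH]c2=O)O1` differs from compound 3 by phenyl in place of cyclopropyl on a saturated chain carbon bound to an aromatic carbon and a double-bonded chain carbon. Without a measured step to rest on, the expected step of a number no higher from compound 3 to compound 4 (the limit leaves the size open) is one of no size beyond the scatter, in no particular direction. The estimate for compound 4 in this assay is therefore 3 h, within a range from 1.5 h to 6 h, and a further limit rather than a number is expected as the likeliest outcome.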

Compound 4, half-life in the Rattus norvegicus assay: > 3 h
Compound 4 gave a limit, no number (the forecaster's own chance of this, stated with the estimate: 70%); the middle value lies on the limit itself.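

In the Rattus norvegicus assay, compound 3 and compound 4 both sit at a limit of the assay, so no step between them can be read: the limit of > 3 h in the Rattus norvegicus assay, at which 4 of the 4 values shown sit.

In a physicochemical assay for solubility, in phosphate buffer, measured as kinetic solubility (a higher number here means a more soluble compound, a lower number a less soluble compound), compound 3 gives 30800 nM and compound 4 gives 32800 nM.

The compounds shown leave open how far any half-life lies past the limit, and so whether phenyl in place of cyclopropyl alters it at all.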